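Aryl substituent swaps on the benzyl ether of the series

The source may hold more compounds than are shown below. What is called first, only, known or untested is meant among the compounds shown, and "the series" means these compounds.

Measured compounds:
Compound 1, `COc1cccc(OC)c1OCCNCCOc1ccccc1OCc1ccc(Cl)cc1`, gives 0.0316 nM in an assay on CHO cells for displacement of a labelled ligand from Alpha-1D adrenergic receptor (Homo sapiens); a higher number here means a weaker inhibitor, a lower number a stronger inhibitor.
Compound 2, `COc1cccc(OC)c1OCCNCCOc1ccccc1OCc1ccccc1C`, gives 0.126 nM in this assay.
Compound 3, `COc1cccc(OC)c1OCCNCCOc1ccccc1OCc1cccc([N+](=O)[O-])c1`, gives 0.0631 nM in this assay.

Compound 3 stands second highest of the three numbers in this assay; its nearest neighbour is compound 2, reached by a 2.0-fold lower number from compound 2 to compound 3 (0.30 log units; within the scatter), and its furthest is compound 1, from which it is reached by a 2.0-fold higher number from compound 1 to compound 3 (0.30 log units; within the scatter), so compound 3 is within the scatter of both. Compound 4, `COc1cccc(COc2ccccc2OCCNCCOc2c(OC)cccc2OC)c1`, differs from compound 3 by methoxy in place of nitro on an aromatic carbon.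

For the measured compounds named here, the steps that bear on this are the three substituent changes on the same ring: a 4.0-fold higher number from compound 1 to compound 2 (0.60 log units; beyond the scatter), the only one beyond the scatter, and the two within it, a 2.0-fold higher number from compound 1 to compound 3 (0.30 log units; within the scatter) and a 2.0-fold lower number from compound 2 to compound 3 (0.30 log units; within the scatter). Across these the ring substituent moves the number only modestly. For compound 4 the expected step is therefore a 1.3-fold higher number from compound 3 to compound 4 (0.10 log units; within the scatter), none beyond the scatter in either direction. Compound 4 is thus estimated at 0.08 nM, with a range from 0.03 nM to 0.2 nM.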

Compound 4, inhibition constant: 0.316 nM
Compound 4: the middle estimate sits 4.0-fold (0.60 log units) below what was measured; the measured number lies above the stated range.
By their numbers in this assay, from the lowest: compounds 1, 3 and 2 (each within the scatter of the next, the first and the last beyond it); then compound 4.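

In this assay, the ring substituent is no longer a near-silent change: compound 4 stands apart from all three earlier compounds, with a 5.0-fold higher number from compound 3 to compound 4 (0.70 log units; beyond the scatter) (a 2.5-fold higher number from compound 2 to compound 4 (0.40 log units; beyond the scatter); a 10-fold higher number from compound 1 to compound 4 (1.00 log units; beyond the scatter)), each step beyond the scatter. The nitro-to-methoxy swap keeps the group at the same place on the ring, so the identity of the group at this position alone moves the number, and 3-methoxyphenyl sits on the weaker side of the three other aryl groups. No measurement here accounts for the change.

Open, on these data alone, is whether a hydroxyl, an amine or a longer ether such as ethoxy at this same place would read with compound 3 or with compound 4. Also open, as far as these compounds go, is whether methoxy at another place on this ring would give a step of the same size.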